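Ring size at the amide carbonyl: cyclobutyl to methylcyclopropyl

The compounds below may be only part of what the source reports. "The series", "measured", "known", "first", "only" and "open" are said of these compounds alone.

Working notes on the series. In an assay on SH-EP1 cells for agonist activity at Neuronal acetylcholine receptor; alpha4/beta2 (Homo sapiens), read by FLIPR and calcium flux (on this read-out higher numbers stand for larger maximal responses and lower numbers for smaller maximal responses), compound 1 `O=C(C1CCC1)N1CC2CC(C1)N2` gives 100%, the highest of the three numbers to hand. Compound 3 `O=C(C1CC=CC1)N1CC2CC(C1)N2` gives 93%, a number within the usual scatter of that of compound 1, so no order between these two can be read. Compound 2 `O=C(C1CCCC1)N1CC2CC(C1)N2` gives 48%, which lies beyond the scatter below compound 1. Within the data shown here, no pair of the three measured compounds differs in a single place, so no measured step is available, and what follows rests on the three values and the structural change alone.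

Compound 4 `C[C@@H]1C[C@@H]1C(=O)N1CC2CC(C1)N2` has not yet been measured in this assay. It differs from compound 1 as follows: a group of 4 heavy atoms (4 carbon; one three-membered non-aromatic ring of carbon only) in place of a group of 4 heavy atoms (4 carbon; one four-membered non-aromatic ring of carbon only), on a carbonyl carbon. The group that enters matches the group that leaves in what is counted, apart from the three-membered ring in place of the four-membered ring and the two defined stereocentres.

The step of a number 15 percentage points lower from compound 1 to compound 4 (beyond the scatter) is expected to be small and downward rather than upward, quite possibly within the scatter, because compound 1 gives 100% and leaves little room above it. Compound 4 is estimated to give 85%, within a range from 55% to 110%.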

Compound 4, largest response reached (Emax), in percent of the reference or control that the assay uses: 88%
Beside the measured number, compound 4's estimate is 3 percentage points below it, within the range that was stated.
By their numbers in this assay, from the lowest: compound 2; then compounds 4, 3 and 1 (each within the scatter of the next, the first and the last beyond it).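

Among these compounds, this is the first single-place step: in this assay, the group with one three-membered non-aromatic ring of carbon only, in place of cyclobutyl on the carbonyl carbon, gives a number 12 percentage points lower from compound 1 to compound 4 (beyond the scatter) and is a modest loss. The position therefore tolerates this change of ring size at an equal count of heavy atoms with most of the maximal response kept, though the step does lie beyond the usual scatter and so cannot be treated as neutral. No measurement to hand bears on why the step has this size.

The entering group differs from cyclobutyl in its ring and also carries two defined stereocentres, so this single step cannot separate the effect of ring size from that of the methyl group or of the stereochemistry. Open as well are how an unsubstituted cyclopropyl, the opposite arrangement at the two stereocentres, or a polar replacement such as an amine or a hydroxyl on the ring would read at this carbonyl carbon on the same core.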